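Swapping the Carbamate Ester on a Dioxygenase Inhibitor

A few compounds are considered here, and "the series" means these few. Any claim that something is new, unique, unknown or untested is made for them only; others in the source may bear on it.

Compound 1 `O=C(NC1(c2ccc3c(n2)CCN3C(=O)OC2CC2)CCC1)c1ccc(Cl)cc1` gives 4.5 nM in an assay on HeLa cells for inhibition of Indoleamine 2,3-dioxygenase 1 (Homo sapiens); on this read-out higher numbers stand for weaker inhibition and lower numbers for stronger inhibition.
Compound 2 `O=C(Nc1ccc(Cl)cc1)C1(c2ccc3c(n2)CCN3c2ccccn2)CCC1` gives 2.3 nM in this assay.

Both values lie within the usual scatter of each other, so compound 1 stands alongside compound 2 rather than apart from it. Compound 3 `COCCOC(=O)N1CCc2nc(C3(NC(=O)c4ccc(Cl)cc4)CCC3)ccc21` keeps the core of compound 1 and differs from it in one place: 2-methoxyethyl in place of cyclopropyl on an oxygen next to a carbonyl group. Among the measured compounds shown here, no measured pair shows this change, so nothing here points in either direction. The step is expected to be a 1.3-fold higher number from compound 1 to compound 3 (0.12 log units; within the scatter), none beyond the scatter. On that basis compound 3 is estimated at 6 nM, between 2 nM and 18 nM.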

Compound 3, half-maximal inhibitory concentration: 6.9 nM
Compound 3: the middle estimate sits 1.2-fold (0.06 log units) below what was measured, and the stated range covers the measured number.
By their numbers in this assay, from the lowest: compounds 2, 1 and 3 (each within the scatter of the next, the first and the last beyond it).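

At this position, the carbamate ester tolerates an open chain in place of a three-membered ring: replacing cyclopropyl with 2-methoxyethyl gives a 1.5-fold higher number from compound 1 to compound 3 (0.19 log units; within the scatter) in this assay. The added chain oxygen, a hydrogen-bond acceptor, therefore brings no change beyond the scatter in this single pair. Nothing available explains this result.

Going by these compounds, it remains open whether a plain butyl chain without that oxygen would give the same reading. A chain ending in an amine or a carboxylic acid is likewise untested by the compounds shown here.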